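Sulfonamide nitrogen substituent in a pyridinone tetrazole series

A few compounds are considered here, and "the series" means these few. Any claim that something is new, unique, unknown or untested is made for them only; others in the source may bear on it.

Measured so far in a functional assay (aorta) for antagonist activity, with Oryctolagus cuniculus as the target; on this read-out lower numbers stand for stronger inhibition and higher numbers for weaker inhibition:
- compound 1 `CCCCc1ccc(CN(C)S(=O)(=O)c2ccccc2)c(=O)n1Cc1ccc(-c2ccccc2-c2nn[nH]n2)cc1`: 2 nM
- compound 2 `CCCCc1ccc(CN(C(C)C)S(C)(=O)=O)c(=O)n1Cc1ccc(-c2ccccc2-c2nn[nH]n2)cc1`: 0.9 nM

Among the compounds with values here, compound 2 holds the lowest number of the two; the one step that separates them is a 2.2-fold lower number from compound 1 to compound 2 (0.35 log units; beyond the scatter). That step changes both the sulfonyl group and the nitrogen substituent at once, so it does not isolate either.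

Compound 3 `CCCCc1ccc(CN(C)S(C)(=O)=O)c(=O)n1Cc1ccc(-c2ccccc2-c2nn[nH]n2)cc1` is not yet measured. It differs from compound 2 by methyl in place of isopropyl on a sulfonamide nitrogen. Within the data shown here, no measured step bears directly on this change alone. In this assay compound 3 is therefore expected near compound 2, with an estimated step of a 1.7-fold higher number from compound 2 to compound 3 (0.22 log units; within the scatter). The estimate for compound 3 is 1.5 nM, within 0.5 nM to 5 nM.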

Compound 3, half-maximal inhibitory concentration: 0.2 nM
For compound 3 the middle estimate is 7.5-fold (0.88 log units) above the measured one; the measured number lies below the stated range.
By their numbers in this assay, from the lowest: compound 3; then compound 2; then compound 1.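

In this assay, methyl in place of isopropyl on a sulfonamide nitrogen now reads alone, as a 4.5-fold lower number from compound 2 to compound 3 (0.65 log units; beyond the scatter). Methyl in place of phenyl on a sulfonyl sulfur also reads alone, as a 10-fold lower number from compound 1 to compound 3 (1.00 log units; beyond the scatter), so the two changes combined in compound 2 pull in opposite directions. No measurement offers a reason for either step.

Only methyl and isopropyl have been compared on the sulfonamide nitrogen, so hydrogen or ethyl there remains an open question. Ethyl or a longer chain on the sulfonyl sulfur is equally open.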